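From 2-fluorophenyl to 3-fluoropyridin-2-yl in compound 3

A few compounds are considered here, and "the series" means these few. Any claim that something is new, unique, unknown or untested is made for them only; others in the source may bear on it.

Measured so far in an ADME assay on microsomes from liver (Homo sapiens) for metabolic stability, read by LC-MS, using NADPH, with stated times of 5 min and 30 min, tested at 1 uM; a lower number here means that less of the compound is left, a higher number that more of the compound is left
Compound 1 `COc1ccccc1S(=O)(=O)/C=C/c1cccnc1OC` gives "not determined" (no result reported)
Compound 2 `O=S(=O)(/C=C/c1ccccc1F)c1ccccn1` gives 91%
Compound 3 `O=S(=O)(/C=C/c1ccccc1F)c1ncccc1C(F)(F)F` gives 97%

Within the data shown here, compound 3 and compound 2 hold the only two numbers, and these lie within the scatter of each other. Compound 4 (`O=S(=O)(/C=C/c1ncccc1F)c1ncccc1C(F)(F)F`) keeps the rest of compound 3 and changes one group (3-fluoropyridin-2-yl in place of 2-fluorophenyl on a double-bonded chain carbon bound to a double-bonded chain carbon). Among the measured compounds shown here, the only measured step (a number 6 percentage points higher from compound 2 to compound 3 (within the scatter)) is a different change, trifluoromethyl in place of hydrogen on an aromatic carbon, and it stays within the scatter. For the measured compounds named here, no measured pair swaps a carbon-only ring for a ring with a hetero atom. Going by the values given here, with compound 2 at 91% and compound 3 at 97% as the only guide, no step beyond the scatter is expected in this assay for this swap. The expected change is small (a number 5 percentage points lower from compound 3 to compound 4 (within the scatter)). Compound 4 is estimated at 92% (expected range 78% to 100%).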

Compound 4, percent of the compound remaining: 98%
The estimate for compound 4 lay 6 percentage points below the measured number; the range from low to high includes it.
By their numbers in this assay, from the lowest: compounds 2, 3 and 4 (each within the scatter of the next).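

In this assay, putting 3-fluoropyridin-2-yl in place of 2-fluorophenyl gives a number 1 percentage points higher from compound 3 to compound 4 (within the scatter), so the swap leaves no readable mark on the number. Among the compounds shown, this is the only pair that exchanges a carbon-only ring for a ring with a hetero atom at this place, and the amount of compound left holds up with that ring. Nothing available explains this result.

Still open, from the compounds shown here alone, is whether an amine or a carboxylic acid on this ring would keep the number this high. All the numbers shown lie close together, so they give no sign of which change at this place would lower it.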